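The compounds below may be only part of what the source reports. "The series", "measured", "known", "first", "only" and "open" are said of these compounds alone.

Compound 1 `O=C(Oc1cccc2cccnc12)c1cc2c(cc1Cl)SC(N(c1ccc(F)cc1)S(=O)(=O)c1ccc(Br)s1)=NS2(=O)=O`: in a functional assay on RT-4 cells (Homo sapiens) for cytotoxicity, with a stated time of 96 h (a higher number here means a weaker inhibitor of growth, a lower number a stronger inhibitor of growth), compound 1 gives > 20000 nM, which is a limit of the assay and not a number.
Compound 2 `COC(=O)c1cc2c(cc1Cl)SC(N(N(C)C)S(=O)(=O)c1ccc(Br)s1)=NS2(=O)=O`: in this assay compound 2 gives 18500 nM.
Compound 3 `Cc1cc2c(cc1Cl)SC(N(c1ccc(Cl)cc1)S(=O)(=O)c1ccccc1)=NS2(=O)=O`: in this assay compound 3 gives 22000 nM.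

Compound 1 stands at the limit of the assay (the limit of > 20000 nM in this assay, at which 1 of the 3 values shown sits), so its place relative to the other two measured compounds cannot be fixed. The values of compound 2 and compound 3 sit within the scatter of each other, and all three measured compounds are weak inhibitors of growth in this assay.

Compound 4 `O=C(Oc1cccc2cccnc12)c1cc2c(cc1Cl)SC(N(c1ccc(F)cc1)S(=O)(=O)c1ccc(Cl)cc1)=NS2(=O)=O` differs from compound 1 in one place: 4-chlorophenyl in place of 5-bromothiophen-2-yl on a sulfonyl sulfur. Going by the values given here, no measured pair isolates this change, so nothing among the measured compounds tells its size or direction. With every measured compound weak, compound 4 is expected to remain weak as well. The step from compound 1 to compound 4 is expected to be a step that the limit leaves unreadable from compound 1 to compound 4, which is no change beyond the scatter. Compound 4 is estimated at 25000 nM, with a range from 8000 nM to 80000 nM, and a good chance that the assay reports only a limit.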

Compound 4, concentration for 50% growth inhibition: > 20000 nM
Compound 4: only a limit was reported; the forecaster's own chance of this, stated with the estimate: 65%; the middle value is on the limit's open side.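

Compound 1 and compound 4 both stand at a limit of the assay and not at a number, so no step between them can be read: the limit of > 20000 nM in this assay, at which 2 of the 4 values shown sit.

The compounds shown leave open whether 4-chlorophenyl in place of 5-bromothiophen-2-yl on a sulfonyl sulfur changes growth inhibition at all, and in which direction.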